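Aldehyde dehydrogenase 1A1 inhibition: a third analogue

A few compounds are considered here, and "the series" means these few. Any claim that something is new, unique, unknown or untested is made for them only; others in the source may bear on it.

compound 1 `Cc1cccc(Cn2c(CN3CCN(C(=O)c4ccc(Br)cc4)CC3)nc3ccccc32)c1`: 25.8%
compound 2 `COc1cccc(Cn2c(CN3CCN(C(=O)C4CC4)CC3)nc3ccccc32)c1`: 44.4%

For the measured compounds named here, in an assay on isolated protein for inhibition of aldehyde dehydrogenase 1A1 (Homo sapiens), read by spectrophotometry, tested at 10 uM (on this read-out lower numbers stand for less inhibition and higher numbers for more inhibition at the one concentration tested (going by the name of the read-out)), compound 2 gives 44.4%, the higher of the two numbers so far; compound 1 gives 25.8%, a gap beyond the usual scatter. Compound 3 `O=C(C1CC1)N1CCN(Cc2nc3ccccc3n2Cc2cccc(Cl)c2)CC1` has not yet been measured there. It differs from compound 2 in one place: chloro in place of methoxy on an aromatic carbon. Going by the values given here, no measured pair shows this change, so its size is unknown from these data; a small step, not clearly beyond the scatter, is expected in either direction. Compound 3 is estimated at 40%, within 22% to 58%. The expected step is a number 4.4 percentage points lower from compound 2 to compound 3 (within the scatter).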

Compound 3, a percentage reported as inhibition, at one concentration (the size of the read-out at that concentration, not a potency): 71.6%
The estimate for compound 3 lay 31.6 percentage points below the measured number; measured number outside the range, above it.
By their numbers in this assay, from the lowest: compound 1; then compound 2; then compound 3.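

In this assay, the position carrying the 3-methoxyphenyl to 3-chlorophenyl change is sensitive to its substituent: chloro in place of methoxy on this aromatic carbon gives a number 27.2 percentage points higher from compound 2 to compound 3 (beyond the scatter). Compound 1 and compound 2 differ in more than one place, so they could not isolate this effect. Nothing on hand accounts for the size of the step. Still open, going by these compounds, is whether fluoro, an amine or a carboxylic acid at this position would keep the level of compound 3. Also open, on these data alone, is whether the step carries over when the other end of the molecule changes.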